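Moving the Methoxy Group Around a Phenyl Ring

This account rests on a few compounds, and the source may have more. Where it says the series, first, only, none or still open, it means among the compounds named here.

Measured compounds:
compound 1, `Oc1cc(C(F)(F)F)ccc1-c1nc(-c2ccccc2O)n(-c2ccc(F)cc2)n1`: 86.7%
compound 2, `COc1ccccc1-n1nc(-c2ccc(C(F)(F)F)cc2O)nc1-c1ccccc1O`: 85.6%

In a functional assay on PC-12 cells (Rattus norvegicus) for cytotoxicity, read by MTT assay, with stated times of 2 h and 24 h, tested at 5 uM (on this read-out higher numbers stand for a stronger effect at the one concentration tested and lower numbers for a weaker effect), compound 1 gives 86.7% and compound 2 gives 85.6%. Compound 2 has the lower of the two numbers, yet the step of a number 1.1 percentage points lower from compound 1 to compound 2 (within the scatter) lies within the scatter, so the two values cannot be told apart. Compound 3, `COc1cccc(-n2nc(-c3ccc(C(F)(F)F)cc3O)nc2-c2ccccc2O)c1`, has not yet been tested in this assay. It differs from compound 2 by 3-methoxyphenyl in place of 2-methoxyphenyl on an aromatic nitrogen. Among the measured compounds shown here, no measured step changes the position of a group on this phenyl ring; the only step known, a number 1.1 percentage points lower from compound 1 to compound 2 (within the scatter), exchanges the whole ring and was within the scatter. Compound 3 is therefore expected to behave much like compound 2, with an estimated step of a number 1.6 percentage points lower from compound 2 to compound 3 (within the scatter), nothing beyond the scatter. For compound 3 the estimate in this assay is 84%, within a range from 70% to 95%.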

Compound 3, a percentage reported as activity, at one concentration (the size of the read-out at that concentration, not a potency): 96.8%
Compound 3: the middle estimate sits 12.8 percentage points below what was measured, outside the stated range (above it).
By their numbers in this assay, from the lowest: compounds 2 and 1 (each within the scatter of the next); then compound 3.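

In this assay, among the compounds shown here, moving the methoxy group on the same phenyl ring gives a number 11.2 percentage points higher from compound 2 to compound 3 (beyond the scatter), the first step to pass beyond the scatter, so where the group sits on this ring counts even with the same atoms. Exchanging the whole ring can therefore count too, depending on the methoxy position: a number 10.1 percentage points higher from compound 1 to compound 3 (beyond the scatter) stands beyond the scatter, whereas a number 1.1 percentage points lower from compound 1 to compound 2 (within the scatter) stands within it. Nothing available explains why the 3-methoxyphenyl compound reads higher.

The compounds shown do not tell whether an amine or a carboxylic acid in place of the methoxy group on this phenyl ring would keep the higher number. They also leave open whether the difference between compound 2 and compound 3 would hold at other concentrations.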